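The compounds below may be only part of what the source reports. "The series", "measured", "known", "first", "only" and "open" are said of these compounds alone.

Measured compounds:
compound 1, `CC(=O)NCCCCNC(=O)c1[nH]cc(C(=O)OC2CC3CCC2C3)c1C`, 200 nM
compound 2, `CCOC(=O)c1[nH]c(C)c(C(=O)OC2CC3CCC2C3)c1C`, 100 nM
compound 3, `COCCNC(=O)c1[nH]cc(C(=O)NC2CC3CCC2C3)c1C`, < 10000 nM

In an assay on CHO cells for inhibition of metabotropic glutamate receptor 1 (Homo sapiens) (a lower number here means a stronger inhibitor, a higher number a weaker inhibitor), compound 1 gives 200 nM. Compound 2 gives 100 nM in this assay, and the two numbers lie within the scatter of each other, so neither can be called the stronger inhibitor. Compound 3 is reported in this assay only as a limit, < 10000 nM, and not as a number; this is the limit named in the limit of < 10000 nM in this assay, at which 1 of the 3 values shown sits. Among the measured compounds shown here, no pair of the measured compounds differs in a single place, so no measured step is available.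

The unmeasured compound 4, `COCCNC(=O)c1[nH]cc(C(=O)OC2CC3CCC2C3)c1C`, is reached from compound 1 by one change: methoxy in place of 2-acetamidoethyl on a saturated chain carbon, two bonds along the chain from an amide-type nitrogen. The change swaps one side chain on the amide for another while the rest of compound 1, including the ester, is kept. For the measured compounds named here, with no measured step to lean on, the step from compound 1 to compound 4 is expected to stay within the scatter, with no clear direction, and is estimated as no change at the digits printed from compound 1 to compound 4 (within the scatter). Compound 4 is therefore expected to give about 200 nM in this assay, with a plausible range from 60 nM to 700 nM.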

Compound 4, half-maximal inhibitory concentration: 158 nM
Compound 4: the middle estimate sits 1.3-fold (0.10 log units) above what was measured; low and high end bracket the measured number.
By their numbers in this assay, from the lowest: compounds 2, 4 and 1 (each within the scatter of the next).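

Among the compounds shown here, compound 4 gives the first measured step on this side chain in this assay, and it reads a 1.3-fold lower number from compound 1 to compound 4 (0.10 log units; within the scatter). Across the two compounds, then, the 4-acetamidobutyl chain can give way to the 2-methoxyethyl chain, with 6 heavy atoms replaced by 2 and the hydrogen-bond donor of the leaving group gone, and no difference in the number can be claimed; this holds for this one pair, with the ester and the rest of the core kept. None of the data shown gives a cause for this step.

Compound 3 carries the same (2-methoxyethyl)amino side chain as compound 4 with an amide in place of the ester. Compound 3 is reported only as a limit, < 10000 nM, so that comparison cannot be read. As far as these compounds go, it remains open whether a side chain ending in an amine or a carboxylic acid, a chain longer than 4-acetamidobutyl, or a chain shorter than 2-methoxyethyl, such as a plain ethyl, would also stay within the scatter of compound 1.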